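The source may hold more compounds than are shown below. What is called first, only, known or untested is meant among the compounds shown, and "the series" means these compounds.

Measured compounds:
Compound 1, `CCCCCCCCCCn1nnnc1NC(=O)Nc1c(C(C)C)cccc1C(C)C`, in an assay on microsomes from intestine for inhibition of acyl-CoA:cholesterol acyltransferase (Oryctolagus cuniculus) (a higher number here means a weaker inhibitor, a lower number a stronger inhibitor), gives 180 nM.
Compound 2, `CCCCCCCCCCCCCCc1cc(NC(=O)Nc2c(C(C)C)cccc2C(C)C)on1`, in this assay gives 28 nM.

Compound 2 carries the lowest of the two numbers; its nearest neighbour, compound 1, gives a number higher by more than the usual scatter. Among the compounds with values here, no step between two measured compounds that differ in one place is available, so these two values stand alone and rest on different cores.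

Compound 3, `CCCCCCCCCCCCCc1cc(NC(=O)Nc2c(C(C)C)cccc2C(C)C)on1`, differs from compound 2 in one place: hydrogen in place of methyl on a saturated chain carbon, ten or more bonds along the chain from an aromatic carbon. The core of compound 2 stays as it is. Within the data shown here, with no measured step of this kind at hand, and the change sitting on a saturated chain carbon, the expectation is for a step in this assay that stays within the scatter, at most tending slightly toward a higher number. Compound 3 is therefore expected to give about 35 nM in this assay, with a range from 15 nM to 80 nM. The step of a 1.3-fold higher number from compound 2 to compound 3 (0.10 log units; within the scatter) that this estimate means is expected to lie within the scatter.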

Compound 3, half-maximal inhibitory concentration: 13 nM
Compound 3: the middle estimate sits 2.7-fold (0.43 log units) above what was measured, outside the stated range (below it).
By their numbers in this assay, from the lowest: compound 3; then compound 2; then compound 1.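

In this assay, hydrogen in place of methyl on a saturated chain carbon, ten or more bonds along the chain from an aromatic carbon, gives a 2.2-fold lower number from compound 2 to compound 3 (0.33 log units; beyond the scatter) and so counts as a modest step that still lies beyond the scatter. This is the only comparison shown between compounds that differ in one place, and it shows that a single methyl this far along the chain is not silent in the read-out, with the shorter chain carrying the lower number. Nothing measured here bears on why the number moves with this change.

From the compounds shown here alone, a single step gives no trend, so it remains open whether a still shorter chain or a longer chain would move the number further, and what a hydroxyl, an amine or a carboxylic acid would do in place of that methyl. Going by these compounds, it also remains open whether the same change would give a step of like size and direction on the core of compound 1, which differs from compound 2 in more than one place.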